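Propoxy to allyloxy: one small chain change on compound 2

This account rests on a few compounds, and the source may have more. Where it says the series, first, only, none or still open, it means among the compounds named here.

Measured so far:
- compound 1, `C=CCOc1ccc(C(=O)Nc2cccc(Br)n2)cc1`: 70100 nM
- compound 2, `CCCNc1cccc(NC(=O)c2ccc(OCCC)cc2)n1`: 15400 nM

In an in vitro assay on HEK-tsA201 cells for antagonist activity at Neuronal acetylcholine receptor; alpha4/beta2 (Homo sapiens), read by fluorescence and calcium flux (a higher number here means a weaker inhibitor, a lower number a stronger inhibitor), compound 2 gives 15400 nM, the lower of the two numbers; compound 1 gives 70100 nM, a gap that lies beyond the usual scatter. Compound 3, `C=CCOc1ccc(C(=O)Nc2cccc(NCCC)n2)cc1`, is compound 2 with one alteration: vinyl in place of ethyl on a saturated chain carbon bound to an oxygen on an aromatic ring. Within the data shown here, compound 1 already carries the allyloxy chain, but it also differs from compound 2 elsewhere, so its value shows only what both differences together give, and no single-change step for this chain swap has been measured. Among the measured compounds shown here, the expected step from compound 2 to compound 3 is therefore small, with no clear direction and likely within the scatter, since only two carbons change and no donor, acceptor or ring is gained or lost. The step I expect is a 1.2-fold higher number from compound 2 to compound 3 (0.07 log units; within the scatter). For compound 3 I estimate 18000 nM, ranging from 7000 nM to 45000 nM.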

Compound 3, half-maximal inhibitory concentration: 14800 nM
Compound 3: middle estimate off by 1.2-fold (0.09 log units), on the high side; measured number inside the range.
By their numbers in this assay, from the lowest: compounds 3 and 2 (each within the scatter of the next); then compound 1.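

In this assay the swap of propoxy for allyloxy gives a 1.0-fold lower number from compound 2 to compound 3 (0.02 log units; within the scatter), so this chain position tolerates vinyl in place of ethyl, at least with propylamino held fixed on the other side of the molecule. With the allyloxy chain held constant, propylamino in place of bromo on an aromatic carbon gives a 4.7-fold lower number from compound 1 to compound 3 (0.68 log units; beyond the scatter), and this is the change of the two that moves the number beyond the scatter. Nothing here measures why either step has the size it has.

The compounds shown leave open whether a longer chain such as butoxy, or benzyloxy, on the same oxygen would also leave the number in place. They also leave open how an amine such as ethylamino or morpholine would compare with propylamino on that aromatic carbon.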